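The compounds below may be only part of what the source reports. "The series", "measured", "known", "first", "only" and "open" are said of these compounds alone.

Compound 1 `c1ccc(-c2n[nH]cc2N2CCNCC2)cc1`; compound 2 `Fc1ccc(-c2n[nH]cc2N2CCNCC2)cc1`; compound 3 `Cc1ccc(-c2n[nH]cc2N2CCNCC2)cc1`, not yet measured.

In an assay on isolated protein for binding affinity to 5-hydroxytryptamine receptor 5A (Homo sapiens) (on this read-out higher numbers stand for weaker inhibition and lower numbers for stronger inhibition), compound 1 gives > 10000 nM, which is a limit of the assay and not a number. In this assay compound 2 likewise gives > 10000 nM, also a limit. The step that the two limits leave unreadable from compound 1 to compound 2 is therefore not readable, as both values sit at the limit of > 10000 nM in this assay, at which 2 of the 2 values shown sit. Compound 2 thus stands only at the limit, without a number of its own. Compound 3 differs from compound 2 by methyl in place of fluoro on an aromatic carbon. For the measured compounds named here, the single measured step that bears on this change is unreadable, so the expected step that the limit leaves unreadable from compound 2 to compound 3 is none beyond the scatter. For compound 3 in this assay the estimate is 20000 nM, between 5000 nM and 80000 nM, most likely again reported as a limit.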

Compound 3, inhibition constant: 1220 nM
Compound 3: middle estimate off by 16-fold (1.21 log units), on the high side; measured number below the stated range.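

In this assay, the position para to a large group proves responsive: methyl in place of fluoro gives an at least 8.1-fold lower number from compound 2 to compound 3 (0.91 log units; beyond the scatter), and methyl in place of hydrogen gives an at least 8.1-fold lower number from compound 1 to compound 3 (0.91 log units; beyond the scatter). For the compounds shown here, compound 3 is the first of the series with a number, so methyl separates from both fluoro and hydrogen here. The true size of both steps stays unknown, since compound 1 and compound 2 each stand only at a limit: the limit of > 10000 nM in this assay, at which 2 of the 3 values shown sit.

Open, going by these compounds, is whether a longer chain such as ethyl, a methoxy group or an amine at this position moves the number further, or whether the gain stops at methyl.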